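An Acid Side Chain in Place of the Amine

The source may report more compounds than this note shows. Statements on the series, on what has been measured and on what is new or still open speak of the compounds shown alone.

Measured so far:
compound 1, `COc1ccccc1OCC1SCCN1C(=O)CN`, 57 mg/kg
compound 2, `CCOC(=O)CCC(=O)N1CCSC1COc1ccccc1OC`, 24 mg/kg
compound 3, `CCOC(=O)CC(=O)N1CCSC1COc1ccccc1O`, 20 mg/kg

Among these three, compound 1 stands highest in a functional assay on the whole organism for inhibition, with Cavia porcellus as the target; on this read-out lower numbers stand for an effect already at smaller amounts and higher numbers for an effect only at larger amounts of compound. Its nearest neighbour is compound 2, and compound 3 lies furthest from it; both of those carry an ester-bearing chain on the carbonyl carbon where compound 1 carries its amine, and both sit lower, beyond the scatter.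

Compound 4, `COc1ccccc1OCC1SCCN1C(=O)C(C)(C)C(=O)O`, is the next member of the series and has not yet been measured. It differs from compound 1 by 1-carboxy-1-methylethyl in place of aminomethyl on a carbonyl carbon, so the chain on the amide carbonyl grows and the terminal amine gives way to a carboxylic acid flanked by two methyl groups.

Going by the values given here, one measured step bears on this: a 2.4-fold lower number from compound 1 to compound 2 (0.38 log units; beyond the scatter), where the amine was likewise exchanged for a longer, carbonyl-bearing chain. That step was modest but real, and compound 3 points the same way. The change to compound 4 is not the same exchange, since an acid rather than an ester enters, but it runs in the same direction of replacing the amine with an oxygen-bearing chain. The account therefore expects a modest step toward a lower number in this assay, about a 1.9-fold lower number from compound 1 to compound 4 (0.28 log units; within the scatter), and estimates for compound 4 a value of 30 mg/kg, within 12 mg/kg to 75 mg/kg.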

Compound 4, dose for half-maximal effect: 34 mg/kg
Compound 4: middle estimate off by 1.1-fold (0.05 log units), on the low side; measured number inside the range.
By their numbers in this assay, from the lowest: compounds 3, 2, 4 and 1 (each within the scatter of the next, the first and the last beyond it).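

Going by these compounds alone, on the carbonyl carbon whose other neighbour is the amide-type nitrogen in a ring, compound 4 shows for the first time how a chain ending in a carboxylic acid reads in this assay: the exchange of aminomethyl for 1-carboxy-1-methylethyl gives a 1.7-fold lower number from compound 1 to compound 4 (0.22 log units; within the scatter), whereas the earlier exchange for the ester chain of compound 2 had gone beyond the scatter. The comparison with that ester chain gives a 1.4-fold higher number from compound 2 to compound 4 (0.15 log units; within the scatter), so compound 4 cannot be separated in this read-out from either compound it is directly compared with. The position thus accepts aminomethyl, 2-(ethoxycarbonyl)ethyl and 1-carboxy-1-methylethyl with only the one step beyond the scatter, and nothing shown here measures anything that would account for these numbers.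

The compounds shown leave open what the methyl groups of 1-carboxy-1-methylethyl contribute, since an unbranched chain ending in a carboxylic acid does not appear among them, nor does the ethyl ester of this branched chain. They also leave open whether an amine carried on a longer chain would read like aminomethyl or like the chains that replaced it.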